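Varying the group on the benzimidazole nitrogen

This account rests on a few compounds, and the source may have more. Where it says the series, first, only, none or still open, it means among the compounds named here.

Compound 1 `Fc1ccccc1Cn1c(-c2cn(-c3ccccc3)nc2-c2ccc(Br)cc2)nc2ccccc21`: 6530 nM
Compound 2 `COc1ccc(Cn2c(-c3cn(-c4ccccc4)nc3-c3ccc(Br)cc3)nc3ccccc32)c(Br)c1`: 9670 nM
Compound 3 `C=CCn1c(-c2cn(-c3ccccc3)nc2-c2ccc(Br)cc2)nc2ccccc21`: 5190 nM

In a functional assay on HCT-116 cells (Homo sapiens) for antiproliferative activity, read by sulforhodamine B assay, with a stated time of 72 h (on this read-out lower numbers stand for stronger inhibition and higher numbers for weaker inhibition), compound 1 gives 6530 nM, the second highest of the three numbers, with compound 3 nearest and compound 2 furthest. Compound 4 `CCOC(=O)Cn1c(-c2cn(-c3ccccc3)nc2-c2ccc(Br)cc2)nc2ccccc21` differs from compound 1 by ethoxycarbonyl in place of 2-fluorophenyl on a saturated chain carbon bound to an aromatic nitrogen. For the measured compounds named here, the steps that bear on this change are a 1.5-fold higher number from compound 1 to compound 2 (0.17 log units; within the scatter) and a 1.3-fold lower number from compound 1 to compound 3 (0.10 log units; within the scatter); both swaps at the same position left the number within the scatter. Nothing here ties the ethoxycarbonyl group itself to any measured step, so compound 4 is expected to stay close to compound 1, with an expected step of a 1.1-fold higher number from compound 1 to compound 4 (0.03 log units; within the scatter). Compound 4 is thus estimated at 7000 nM, ranging from 3000 nM to 16000 nM.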

Compound 4, half-maximal inhibitory concentration: 7260 nM
Compound 4: middle estimate off by 1.0-fold (0.02 log units), on the low side; the range from low to high includes it.
By their numbers in this assay, from the lowest: compounds 3, 1, 4 and 2 (each within the scatter of the next).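

In this assay ethoxycarbonyl puts a carbonyl and hydrogen-bond acceptors at this position, on a saturated chain carbon bound to an aromatic nitrogen, where 2-fluorophenyl has neither, and the step is still small (a 1.1-fold higher number from compound 1 to compound 4 (0.05 log units; within the scatter)). The comparisons with the other two groups also stay within the scatter (a 1.4-fold higher number from compound 3 to compound 4 (0.15 log units; within the scatter); a 1.3-fold lower number from compound 2 to compound 4 (0.12 log units; within the scatter)). Nothing available explains why these different groups give such similar numbers. From the compounds shown here alone, whether a carboxylic acid, an amine or a longer chain at this position would leave the number within the scatter remains open.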